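Amide variations on a shared core against NOTUM

The compounds below may be only part of what the source reports. "The series", "measured", "known", "first", "only" and "open" are said of these compounds alone.

Measured compounds:
- compound 1 `O=C(O)C1CCN(c2cccc(C(F)(F)F)c2)C1`: 11000 nM
- compound 2 `O=C(Nc1ccccc1)C1CCN(c2ccc(Cl)c(C(F)(F)F)c2)C1`: 1000 nM
- compound 3 `CN(C)C(=O)C1CCN(c2ccc(Cl)c(C(F)(F)F)c2)C1`: 1200 nM

In an assay on cells for inhibition of Palmitoleoyl-protein carboxylesterase NOTUM variant C330S (Homo sapiens), read by fluorescence, with a stated time of 40 min (on this read-out higher numbers stand for weaker inhibition and lower numbers for stronger inhibition), compound 3 stands second highest of the three numbers; compound 2 lies within the scatter of it, and compound 1 sits far higher. Compound 4 `O=C(C1CCN(c2ccc(Cl)c(C(F)(F)F)c2)C1)N1CC2COCC2C1` differs from compound 3 by a group of 8 heavy atoms (6 carbon, 1 nitrogen, 1 oxygen; 2 five-membered non-aromatic rings with 1 hetero atom each) in place of a group of 3 heavy atoms (2 carbon, 1 nitrogen; no ring), on a carbonyl carbon. For the measured compounds named here, the only measured step at that same carbonyl carbon is a 1.2-fold higher number from compound 2 to compound 3 (0.08 log units; within the scatter), which changed nothing beyond the scatter. On that basis, another exchange of the amine at the carbonyl is expected to move the number little, in no clear direction. Compound 4 is therefore estimated at 1200 nM, with a range from 400 nM to 3600 nM. This estimate means an expected no change at the digits printed from compound 3 to compound 4 (within the scatter).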

Compound 4, half-maximal inhibitory concentration: 3100 nM
Beside the measured number, compound 4's estimate is 2.6-fold (0.41 log units) below it; the measured number falls inside the stated range.
By their numbers in this assay, from the lowest: compounds 2 and 3 (each within the scatter of the next); then compound 4; then compound 1.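

The group on this carbonyl carbon can change the number after all: the group with two five-membered rings gives a 2.6-fold higher number from compound 3 to compound 4 (0.41 log units; beyond the scatter) and also a 3.1-fold higher number from compound 2 to compound 4 (0.49 log units; beyond the scatter). Both steps are modest, but they lie beyond the scatter, whereas anilino and dimethylamino could not be told apart. Nothing available here accounts for this weaker inhibition. Still open, on these data alone, is whether the ring oxygen or the two rings matter more, and whether diethylamino or methylamino would stay close to compound 3.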